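Bridged Cyclic Amine Replaces the Acetamidopyrrolidine

This account rests on a few compounds, and the source may have more. Where it says the series, first, only, none or still open, it means among the compounds named here.

Compound 3 `CC(=O)NC1CCN(c2ccc3cc(NC(=O)CCc4ccc(C(F)(F)F)cc4)ccc3n2)C1` gives 5 nM in an assay on isolated protein for displacement of a labelled ligand from melanin-concentrating hormone receptor 1 (Homo sapiens) (on this read-out higher numbers stand for weaker inhibition and lower numbers for stronger inhibition), level with compound 1 `CC1CCCN1c1ccc2cc(NC(=O)CCc3ccc(C(F)(F)F)cc3)ccc2n1` at 5 nM and together the lowest of the three numbers; compound 2 `CN(C)c1ccc2cc(NC(=O)CCc3ccc(C(F)(F)F)cc3)ccc2n1` gives 13 nM, the step being a 2.6-fold lower number from compound 2 to compound 3 (0.41 log units; beyond the scatter). Compound 4 `O=C(CCc1ccc(C(F)(F)F)cc1)Nc1ccc2nc(N3CC4CCC3C4)ccc2c1` carries the change (a group of 7 heavy atoms (6 carbon, 1 nitrogen; one five-membered non-aromatic ring of carbon only, one five-membered non-aromatic ring with 1 hetero atom) in place of a group of 9 heavy atoms (6 carbon, 2 nitrogen, 1 oxygen; one five-membered non-aromatic ring with 1 hetero atom), on an aromatic carbon). Two measured steps at this aromatic carbon bear on it: no change at the digits printed from compound 1 to compound 3 (within the scatter) shows that swapping one cyclic amine for another left the number unchanged, while a 2.6-fold higher number from compound 1 to compound 2 (0.41 log units; beyond the scatter) shows the open dimethylamino giving a modestly higher number. The entering group is again a cyclic amine. For compound 4 the expected step is therefore a 1.2-fold higher number from compound 3 to compound 4 (0.08 log units; within the scatter), no more than the scatter. Compound 4 is estimated at 6 nM, within 2.5 nM to 15 nM.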

Compound 4, half-maximal inhibitory concentration: 1 nM
For compound 4 the middle estimate is 6.0-fold (0.78 log units) above the measured one, outside the stated range (below it).
By their numbers in this assay, from the lowest: compound 4; then compounds 1 and 3 (each within the scatter of the next); then compound 2.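

In this assay the two earlier pyrrolidine amines sat level, so changing the cyclic amine had not moved the number, but the bridged two-ring amine does, with a 5.0-fold lower number from compound 3 to compound 4 (0.70 log units; beyond the scatter) and a 5.0-fold lower number from compound 1 to compound 4 (0.70 log units; beyond the scatter) at this aromatic carbon. The gap to the open dimethylamino also grows, with a 13-fold lower number from compound 2 to compound 4 (1.11 log units; beyond the scatter) as the largest step in this set. Nothing measured here explains the gain from the bridged amine. On these data alone, it remains open whether a piperidine or a larger bridged amine would give a similar number, and whether an acetamide on the bridged ring would keep it.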